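Notes on the step to compound 3

The source may hold more compounds than are shown below. What is called first, only, known or untested is meant among the compounds shown, and "the series" means these compounds.

- Compound 1 `COc1cc(Cn2c(=O)cc(N3CCC[C@@H](N)C3)n(Cc3cc(F)ccc3C#N)c2=O)cc(Br)c1OC`: 3.49
- Compound 2 `N#Cc1ccc(F)cc1Cn1c(N2CCC[C@@H](N)C2)cc(=O)n(Cc2cc(F)cc(F)c2)c1=O`: 3.23

In a physicochemical assay for lipophilicity (a lower number here means a more polar compound, a higher number a more lipophilic compound), compound 2 stands at 3.23, within the scatter of compound 1. Compound 3 `CCCCCCCCCCn1c(=O)cc(N2CCC[C@@H](N)C2)n(Cc2cc(F)ccc2C#N)c1=O` has not been measured. The structural change to it is nonyl in place of 3,5-difluorophenyl on a saturated chain carbon bound to an aromatic nitrogen. Cut one bond further out, the same difference reads 3,5-difluorobenzyl to decyl.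

For the measured compounds named here, only one measured step bears on this position: a number 0.26 log units lower from compound 1 to compound 2 (within the scatter). That step exchanges 3-bromo-4,5-dimethoxyphenyl for 3,5-difluorophenyl, so a ring stands on both sides of it. Going by the values given here, in the step to compound 3 the ring leaves and no ring enters, and no measured compound carries such a chain. The measured step therefore gives little guide to size, and the range must stay wide. From the structural change alone, a rise beyond the scatter is expected, and the expected step is a number 1.77 log units higher from compound 2 to compound 3 (beyond the scatter). Compound 3 is estimated at 5, with an expected range of 4.2 to 5.8.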

Compound 3, partition coefficient: 4.93
Beside the measured number, compound 3's estimate is 0.07 log units above it; measured number inside the range.
By their numbers in this assay, from the lowest: compounds 2 and 1 (each within the scatter of the next); then compound 3.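

At the position on a saturated chain carbon bound to an aromatic nitrogen, nonyl in place of 3,5-difluorophenyl gives a number 1.70 log units higher from compound 2 to compound 3 (beyond the scatter) in this assay, and nonyl in place of 3-bromo-4,5-dimethoxyphenyl gives a number 1.44 log units higher from compound 1 to compound 3 (beyond the scatter) in the same read-out. The exchange of one substituted phenyl for another had stayed within the scatter, so it gave no view of how far the number can move here; an open chain in place of either ring now shows a large step beyond the scatter from both ring-bearing compounds. Nothing measured here bears on why the step takes this size.

Compound 3 differs from compound 1 and compound 2 both in losing the aromatic ring and in carrying the long chain, so the share of each in the step remains unresolved. A shorter chain such as butyl, a saturated ring such as cyclohexyl, or a nonyl chain ending in an amine or a carboxylic acid would test how the number at this position depends on chain length, on the ring and on a polar end group.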